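Three limits and the step to compound 4

A few compounds are considered here, and "the series" means these few. Any claim that something is new, unique, unknown or untested is made for them only; others in the source may bear on it.

In an ADME assay on HEK293 cells (Homo sapiens) for cytotoxicity, read by ATP content, with a stated time of 6 h (a lower number here means that less compound is tolerated, a higher number that more compound is tolerated), compound 3 `CC(Nc1nc(N)nc2ccn(Cc3ccccn3)c12)c1ccccn1` gives > 24000 nM as its reading, which is a limit and not a number. Compound 1 `CCCCNc1nc(N)nc2ccn(Cc3ccccn3)c12` gives > 24000 nM as its reading, also a limit. Compound 2 `Cc1ccc(CNc2nc(N)nc3ccn(Cc4ccccn4)c23)nc1` gives > 24000 nM as its reading, again a limit. Compound 4 `Cc1cnc(CNc2nc(N)nc3ccn(Cc4ccccn4)c23)s1` has (5-methyl-1,3-thiazol-2-yl)methyl in place of 1-(pyridin-2-yl)ethyl on a nitrogen on an aromatic ring. The measured changes, a step that the two limits leave unreadable from compound 1 to compound 3 and a step that the two limits leave unreadable from compound 2 to compound 3 and a step that the two limits leave unreadable from compound 1 to compound 2 as well, have no readable size. What remains is the limit of > 24000 nM in this assay, at which 3 of the 3 values shown sit, as the whole record. Expected here is a step that the limit leaves unreadable from compound 3 to compound 4 and no step beyond the scatter. Compound 4 is estimated at 30000 nM with an expected range from 15000 nM to 60000 nM in this assay as its likely reading.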

Compound 4, half-maximal cytotoxic concentration: > 24000 nM
Compound 4 gave a limit, no number; the forecaster's own chance of this, stated with the estimate: 85%; the middle value is on the limit's open side.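

Compound 4 also gives only a limit, so its steps from compound 1, compound 2 and compound 3 cannot be read. The compounds shown leave open whether these four differ at all in how much is tolerated: the limit of > 24000 nM in this assay, at which 4 of the 4 values shown sit.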